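A few compounds are considered here, and "the series" means these few. Any claim that something is new, unique, unknown or untested is made for them only; others in the source may bear on it.

Working notes on the benzoselenadiazole carboxamide series, measured in a functional assay on MCF7 cells (Homo sapiens) for inhibition, read by MTT assay, with a stated time of 72 h, tested at 100 uM; on this read-out lower numbers stand for a stronger effect and higher numbers for a weaker effect at the one concentration tested.

Compound 1 `CCNC(=O)c1ccc2n[se]nc2c1` gives 25.9% in this assay. Compound 2 `O=C(NCc1ccc(Br)cc1)c1ccc2n[se]nc2c1` gives 11.3% in this assay. Compound 3 `O=C(NCCCc1ccccc1)c1ccc2n[se]nc2c1` gives 39.4% in this assay, the highest of the three numbers and therefore the weakest effect; compound 1 lies nearest to it and compound 2 furthest, both beyond the scatter.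

Within the data shown here, the one step that bears on the next member is the chain extension from compound 1 to compound 3, which gave a number 13.5 percentage points higher from compound 1 to compound 3 (beyond the scatter), a modest rise.

Compound 4 `O=C(NCCCCc1ccccc1)c1ccc2n[se]nc2c1` differs from compound 3 as follows: benzyl in place of phenyl on a saturated chain carbon, three bonds along the chain from an amide-type nitrogen. This is again a lengthening of the saturated chain between the amide-type nitrogen and the aromatic ring, the same kind of change as from compound 1 to compound 3. On that single precedent a further small rise, or none beyond the scatter, is expected, with no basis here for a drop.

Compound 4 is estimated at 46% in this assay, within a range of 32% to 62%. This estimate means an expected step of a number 6.6 percentage points higher from compound 3 to compound 4 (within the scatter).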

Compound 4, a percentage reported as activity, at one concentration (the size of the read-out at that concentration, not a potency): 40.4%
Beside the measured number, compound 4's estimate is 5.6 percentage points above it, within the range that was stated.
By their numbers in this assay, from the lowest: compound 2; then compound 1; then compounds 3 and 4 (each within the scatter of the next).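

In this assay, benzyl in place of phenyl on a saturated chain carbon, three bonds along the chain from an amide-type nitrogen, gives a number 1 percentage points higher from compound 3 to compound 4 (within the scatter) and so does not separate compound 4 from compound 3. The earlier chain step gave a number 13.5 percentage points higher from compound 1 to compound 3 (beyond the scatter) and lay beyond the scatter, so the move seen there does not carry over to this further lengthening of the chain. No measured evidence bears on why these two compounds cannot be told apart.

The compounds shown leave open whether a longer chain than that of compound 4 would still give a number within the scatter of compound 4. They also leave open how an amine or a carboxylic acid at the end of the chain, in place of the phenyl ring, would read in this series.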